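This account rests on a few compounds, and the source may have more. Where it says the series, first, only, none or still open, it means among the compounds named here.

Measured in a functional assay on MCF7 cells (Homo sapiens) for antiproliferative activity, read by MTT assay, with a stated time of 48 h; on this read-out lower numbers stand for stronger inhibition and higher numbers for weaker inhibition:
Compound 1 `CCn1c(C(=O)NCCCN(C)C)ccc1C(CC)(CC)c1ccc(OCCC(O)(CC)CC)c(C)c1`: 3350 nM
Compound 2 `CCC(C)C(NC(=O)c1ccc(C(CC)(CC)c2ccc(OCCC(O)(CC)CC)c(C)c2)n1CC)C(=O)OC`: > 50000 nM

Compound 2 has no number, only a limit of the assay: > 50000 nM.

Compound 3 `CCn1c(C(=O)N(C)CC(=O)O)ccc1C(CC)(CC)c1ccc(OCCC(O)(CC)CC)c(C)c1` keeps the shared core and changes the group on a carbonyl carbon, where (carboxymethyl)(methyl)amino enters: a group of 6 heavy atoms (3 carbon, 1 nitrogen, 2 oxygen; no ring) in place of a group of 10 heavy atoms (7 carbon, 1 nitrogen, 2 oxygen; no ring), on a carbonyl carbon.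

Going by the values given here, the one measured step bearing on this is an at least 14-fold higher number from compound 1 to compound 2 (1.17 log units; beyond the scatter), a large one that ends at the limit, so it fixes no exact size. Compound 3 is expected to stay closer to compound 2 than to compound 1. The step expected in this assay is small: an at least 1.2-fold lower number from compound 2 to compound 3 (0.09 log units; that floor lies within the scatter). For compound 3 the estimate is 40000 nM, with an expected range of 10000 nM to 100000 nM.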

Compound 3, half-maximal inhibitory concentration: 79 nM
Compound 3: middle estimate off by 510-fold (2.70 log units), on the high side; measured number below the stated range.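

In this assay, the group on this carbonyl carbon can drive the read-out strongly down as well as up: (carboxymethyl)(methyl)amino gives an at least 630-fold lower number from compound 2 to compound 3 (2.80 log units; beyond the scatter). Compound 2 carries only a limit of the assay, so the size of that step is a floor: the limit of > 50000 nM in this assay, at which 1 of the 3 values shown sits. Measured against the (3-(dimethylamino)propyl)amino group, the same entering group gives a 42-fold lower number from compound 1 to compound 3 (1.63 log units; beyond the scatter), so the drop also holds between two real numbers.

From the compounds shown here alone, whether the carboxylic acid itself carries the lower number stays open. A methyl ester of compound 3, or a longer chain in place of carboxymethyl, would be needed to tell.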